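A few compounds are considered here, and "the series" means these few. Any claim that something is new, unique, unknown or untested is made for them only; others in the source may bear on it.

Working notes on the series. Compound 1 `CS(=O)(=O)c1ccc(C(=O)NCCC(=O)N2CCCCC2)cc1[N+](=O)[O-]` is the reference point. In an assay on isolated protein for inhibition of thyroid hormone receptor beta (Homo sapiens), read by fluorescence polarization (a higher number here means a weaker inhibitor, a lower number a stronger inhibitor), compound 1 gives > 60000 nM, which is a limit of the assay and not a number. Compound 2 `CC1Cc2ccccc2N1C(=O)C1CCN(C(=O)c2ccc(S(C)(=O)=O)c([N+](=O)[O-])c2)CC1` gives > 60000 nM in this assay, again a limit. Compound 3 `CS(=O)(=O)c1ccc(C(=O)NCCCC(=O)N2CCC(c3ccccc3)CC2)cc1[N+](=O)[O-]` gives > 60000 nM in this assay, also a limit. All three measured values therefore sit at the limit of > 60000 nM in this assay, at which 3 of the 3 values shown sit, so compound 1 cannot be ranked against the others, and no measured step between any pair of these compounds exists. Compound 4 `CS(=O)(=O)c1ccc(C(=O)NCCC(=O)N2CCc3ccccc3C2)cc1[N+](=O)[O-]` remains to be measured in this assay; it differs from compound 1 by 1,2,3,4-tetrahydroisoquinolin-2-yl in place of piperidin-1-yl on a carbonyl carbon. No step beyond the usual scatter is expected in either direction, so the step is expected to be a number no higher from compound 1 to compound 4 (the limit leaves the size open). Compound 4 is expected to stay at the limit, estimated at 60000 nM with a range from 20000 nM to 60000 nM.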

Compound 4, half-maximal inhibitory concentration: > 60000 nM
Compound 4 gave a limit, no number; the forecaster's own chance of this, stated with the estimate: 85%; the middle value lies on the limit itself.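

Among the compounds shown here, compound 1 and compound 4 both give only a limit of the assay and not a number, so no step between them can be read. The compounds shown leave open whether any change to the shared core gives a measurable value.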